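Swapping the Aryl Group: From Iodine to Methyl

The source may hold more compounds than are shown below. What is called first, only, known or untested is meant among the compounds shown, and "the series" means these compounds.

Of the compounds shown here, three of a shared core have been tested in a functional assay (muscle tissue) with Cavia porcellus as the target; a higher number here means that more compound is needed for the effect, a lower number that less compound is needed. Compound 1 `COC(=O)C1=C(C)N=C(C)/C(=C(\O)OC)C1c1cc(OC)c(OC)cc1OC` gives 1000000 nM, compound 2 `COC(=O)C1=C(C)N=C(C)/C(=C(\O)OC)C1c1ccc(I)cc1` gives 22900 nM, and compound 3 `COC(=O)C1=C(C)N=C(C)/C(=C(/O)OC)C1c1cccc(Cl)c1` gives 15.9 nM. Compound 2 thus stands second highest of the three numbers: compound 1 sits far above it, beyond the usual scatter, and compound 3 sits far below it, also beyond the scatter.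

Compound 4 `COC(=O)C1=C(C)N=C(C)/C(=C(\O)OC)C1c1ccccc1C` is not yet measured. It differs from compound 2 in one place: 2-methylphenyl in place of 4-iodophenyl on a saturated ring carbon. Because compound 3 reaches 15.9 nM with a different single substituent on the same aryl ring, a substantially lower number is expected for compound 4 as well. The step is estimated as a 460-fold lower number from compound 2 to compound 4 (2.66 log units; beyond the scatter), a large move toward less compound being needed. In this assay compound 4 is expected to give about 50 nM, with a plausible range from 5 nM to 500 nM.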

Compound 4, half-maximal effective concentration: 6.03 nM
Beside the measured number, compound 4's estimate is 8.3-fold (0.92 log units) above it; low and high end bracket the measured number.
By their numbers in this assay, from the lowest: compound 4; then compound 3; then compound 2; then compound 1.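

In this assay, for the compounds shown here, the swap of 4-iodophenyl for 2-methylphenyl gives a 3800-fold lower number from compound 2 to compound 4 (3.58 log units; beyond the scatter), the first step here between compounds that differ in one place. It shows that the aryl group on this saturated ring carbon can by itself shift the number enormously. The two groups match in heavy-atom count, each has one aromatic ring of carbon only, and neither has a hydrogen-bond donor or acceptor, so these counts do not track the change, and no measurement shown here gives a cause for it.

From the compounds shown here alone, this one step changes both the substituent and where it sits on the phenyl ring, so the share of each remains open; 2-iodophenyl and 4-methylphenyl would separate them. Also open, going by these compounds, is how this position responds to a phenyl ring carrying an amine or a carboxylic acid.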